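Trading a trichlorophenyl for a bare phenyl

This account rests on a few compounds, and the source may have more. Where it says the series, first, only, none or still open, it means among the compounds named here.

Compound 1, with the structure `CN(C)C/C=C/C(=O)Nc1cccc(S(=O)(=O)N2CCC(NC(=O)c3n[nH]cc3NC(=O)c3c(Cl)cc(Cl)cc3Cl)CC2)c1`, is a candidate inhibitor of a kinase. In an assay on HEK293 cells for inhibition of cyclin-dependent kinase 14 (Homo sapiens), with a stated time of 4 h (a lower number here means a stronger inhibitor, a higher number a weaker inhibitor), compound 1 returns only a limit, >= 500 nM, so the assay gives no exact number for it. Going by the values given here, the one other measured compound, compound 2 with the structure `CN(C)CC/C=C/C(=O)Nc1cccc(N2CCC(NC(=O)c3n[nH]cc3NC(=O)c3c(Cl)cccc3Cl)CC2)c1`, carries a dichlorophenyl group in place of the trichlorophenyl and lacks the sulfonyl link; in this assay compound 2 gives 1000 nM. Both measured compounds therefore sit at the weak end of what this assay can report, as shown by the limit of >= 500 nM in this assay, at which 1 of the 2 values shown sits.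

The unmeasured compound 3, with the structure `CN(C)C/C=C/C(=O)Nc1cccc(S(=O)(=O)N2CCC(NC(=O)c3n[nH]cc3NC(=O)c3ccccc3)CC2)c1`, differs from compound 1 in one place: phenyl in place of 2,4,6-trichlorophenyl on a carbonyl carbon. Among the compounds with values here, no measured pair in this small set tests that change on its own, so the expected size of the step rests on the limit for compound 1 alone. The step is expected to lie at or beyond the usual scatter, toward weaker inhibition; its expected size is a step that the limit leaves unreadable from compound 1 to compound 3. Compound 3 is estimated to give 1500 nM in this assay, within a range from 400 nM to 6000 nM.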

Compound 3, half-maximal inhibitory concentration: 1000 nM
Beside the measured number, compound 3's estimate is 1.5-fold (0.18 log units) above it, within the range that was stated.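

No step from compound 1 to compound 3 can be read, because compound 1 has only a limit, not an exact number, in this assay: the limit of >= 500 nM in this assay, at which 1 of the 3 values shown sits.

The compounds shown leave open how large the change from 2,4,6-trichlorophenyl to phenyl on a carbonyl carbon is, and even whether it strengthens or weakens inhibition.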